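Second methoxy on the aryl ring of the aminopyrimidine series

The source may report more compounds than this note shows. Statements on the series, on what has been measured and on what is new or still open speak of the compounds shown alone.

Compound 3 `COc1ccc(-c2nc(SC)nc(NCCCCNc3ccnc4cc(Cl)ccc34)c2C#N)cc1` stands, in an ADME assay on Vero cells (Chlorocebus sabaeus) for cytotoxicity, read by microscopy (a lower number here means that less compound is tolerated, a higher number that more compound is tolerated), at 20000 nM, level with compound 1 `CSc1nc(NCCCCNc2ccnc3cc(Cl)ccc23)c(C#N)c(-c2ccccc2)n1`, which gives 20000 nM in the same assay; together these are the highest numbers of the three measured. Compound 2 `CSc1nc(NCCCCNc2ccnc3cc(Cl)ccc23)c(C#N)c(-c2ccc([N+](=O)[O-])cc2)n1` gives 4000 nM, the step being a 5.0-fold lower number from compound 1 to compound 2 (0.70 log units; beyond the scatter). Compound 4 `COc1ccc(-c2nc(SC)nc(NCCCCNc3ccnc4cc(Cl)ccc34)c2C#N)cc1OC` differs from compound 3 by methoxy in place of hydrogen on an aromatic carbon, so that the 4-methoxyphenyl becomes a 3,4-dimethoxyphenyl.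

The step that bears directly on this change is no change at the digits printed from compound 1 to compound 3 (within the scatter), the same methoxy-for-hydrogen exchange on the same ring. Among the measured compounds shown here, the only other step on that ring, a 5.0-fold higher number from compound 2 to compound 3 (0.70 log units; beyond the scatter), concerns a different entering group. For the measured compounds named here, the single comparable precedent gave no movement, and nothing here suggests a second methoxy should behave otherwise; the expected step is therefore no change at the digits printed from compound 3 to compound 4 (within the scatter), none beyond the scatter. For compound 4 the estimate in this assay is 20000 nM, with a range of 10000 nM to 40000 nM.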

Compound 4, minimum cytotoxic concentration: > 100000 nM
Compound 4: no number, only a limit (the forecaster's own chance of this, stated with the estimate: 20%); middle value at least 5.0-fold (0.69 log units) away from the limit.
By their numbers in this assay, from the lowest: compound 2; then compounds 1 and 3 (each within the scatter of the next). At a limit, above all of these: compound 4.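

In this assay compound 4 gives > 100000 nM, which is a limit of the assay and not a number. Methoxy in place of hydrogen left the number unchanged on the unsubstituted phenyl ring (no change at the digits printed from compound 1 to compound 3 (within the scatter)), but the same exchange ortho to a methoxy group gives an at least 5.0-fold higher number from compound 3 to compound 4 (0.69 log units; beyond the scatter), so the outcome of this exchange on the ring is not the same at every place. The 3,4-dimethoxyphenyl also separates compound 4 from the other two aryl groups, with an at least 5.0-fold higher number from compound 1 to compound 4 (0.69 log units; beyond the scatter) and an at least 25-fold higher number from compound 2 to compound 4 (1.39 log units; beyond the scatter).

As far as these compounds go, how far compound 4 lies beyond its limit remains open, so each of these steps gives only a lower bound. Also open, from the compounds shown here alone, is whether a lone methoxy at this place, or a hydroxyl, an ethoxy or an amine there, would give a similar step.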